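This account rests on a few compounds, and the source may have more. Where it says the series, first, only, none or still open, it means among the compounds named here.

Three compounds share one core and differ only in the substituent on the phenyl ring attached to the nitrogen. Compound 1 `FC(F)(F)c1ccc(CSc2nc(Nc3ccccc3)c3ccccc3n2)cc1` gives 26400 nM in a functional assay on HGC-27 cells (Homo sapiens) for cytotoxicity, read by MTT assay, with a stated time of 72 h; a higher number here means a weaker inhibitor, a lower number a stronger inhibitor. Compound 2 `FC(F)(F)c1ccc(CSc2nc(Nc3ccccc3Cl)c3ccccc3n2)cc1` gives > 50000 nM, which is a limit of this assay rather than a number (the limit of > 50000 nM in this assay, at which 1 of the 3 values shown sits). Compound 3 `FC(F)(F)c1ccc(CSc2nc(Nc3cccc(C(F)(F)F)c3)c3ccccc3n2)cc1` gives 11700 nM, the lowest of the two numbers measured, and the step of a 2.3-fold lower number from compound 1 to compound 3 (0.35 log units; beyond the scatter) is modest. Compound 4 `FC(F)(F)c1ccc(CSc2nc(Nc3cccc(Cl)c3)c3ccccc3n2)cc1` keeps the core and changes (chloro in place of trifluoromethyl on an aromatic carbon). The step of an at least 1.8-fold higher number from compound 1 to compound 2 (0.27 log units; that floor lies within the scatter) shows that bringing in a chloro reached only a limit, while an at least 4.2-fold lower number from compound 2 to compound 3 (0.63 log units; beyond the scatter) runs in favour of the trifluoromethyl group. Compound 4 is therefore expected to show only a small change, a 1.5-fold higher number from compound 3 to compound 4 (0.19 log units; within the scatter), and is estimated at 18000 nM, between 8000 nM and 45000 nM.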

Compound 4, half-maximal inhibitory concentration: 19900 nM
Compound 4: the middle estimate sits 1.1-fold (0.04 log units) below what was measured; the range from low to high includes it.
By their numbers in this assay, from the lowest: compounds 3, 4 and 1 (each within the scatter of the next, the first and the last beyond it). At a limit, above all of these: compound 2.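

On this aromatic carbon, chloro and trifluoromethyl cannot be told apart in this assay, with a 1.7-fold higher number from compound 3 to compound 4 (0.23 log units; within the scatter), and chloro cannot be told apart from hydrogen, with a 1.3-fold lower number from compound 1 to compound 4 (0.12 log units; within the scatter). Chloro as such therefore does not go with the poor result of compound 2, since the 3-chlorophenyl group in place of 2-chlorophenyl gives an at least 2.5-fold lower number from compound 2 to compound 4 (0.40 log units; beyond the scatter), so in this pair the place of the chloro matters. The value of compound 2 is a limit, not a number: the limit of > 50000 nM in this assay, at which 1 of the 4 values shown sits.

Going by these compounds, what an amine or a carboxylic acid would give on this carbon stays open.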